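The source may hold more compounds than are shown below. What is called first, only, known or untested is meant among the compounds shown, and "the series" means these compounds.

Among the compounds with values here, in a functional assay on MCF7 cells (Homo sapiens) (a higher number here means a weaker inhibitor, a lower number a stronger inhibitor), compound 3 `COc1cc(NC(C)CCCNC(=O)NOCc2ccccc2)c2ncccc2c1` gives 9000 nM, the lowest number of the three measured so far. By comparison, compound 1 `COc1cc(NC(C)CCCNC(=O)NCCCO)c2ncccc2c1` gives 31000 nM and compound 2 `COc1cc(NC(C)CCCNC(=O)NCCCCCO)c2ncccc2c1` gives 44000 nM. Compound 4 `COc1cc(NC(C)CCCNC(=O)NC(CO)(CO)CO)c2ncccc2c1` puts 2-hydroxy-1,1-bis(hydroxymethyl)ethyl in place of benzyloxy on the amide-type nitrogen: 2-hydroxy-1,1-bis(hydroxymethyl)ethyl in place of benzyloxy on an amide-type nitrogen. The nearest evidence is the move from a hydroxyl-ended chain to benzyloxy at that nitrogen, seen as a 3.4-fold lower number from compound 1 to compound 3 (0.54 log units; beyond the scatter) and a 4.9-fold lower number from compound 2 to compound 3 (0.69 log units; beyond the scatter), both modest. Within the data shown here, compound 4 reverses that kind of move, although no measured compound carries its exact group, so a modest rise is expected rather than a large one. The expected change is a 3.3-fold higher number from compound 3 to compound 4 (0.52 log units; beyond the scatter). For compound 4 the estimated value is 30000 nM, with a range of 10000 nM to 90000 nM.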

Compound 4, half-maximal inhibitory concentration: 24000 nM
For compound 4 the middle estimate is 1.3-fold (0.10 log units) above the measured one; low and high end bracket the measured number.
By their numbers in this assay, from the lowest: compound 3; then compounds 4, 1 and 2 (each within the scatter of the next).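

Replacing benzyloxy with 2-hydroxy-1,1-bis(hydroxymethyl)ethyl on the amide-type nitrogen gives a 2.7-fold higher number from compound 3 to compound 4 (0.43 log units; beyond the scatter) in this assay and removes the only ring among these groups. With a 1.8-fold lower number from compound 2 to compound 4 (0.26 log units; within the scatter) and a 1.3-fold lower number from compound 1 to compound 4 (0.11 log units; within the scatter) both printed as within the scatter, this branched group cannot be told apart from the two straight hydroxyl-ended chains, so compound 3 alone stands apart. Nothing given here explains this result.

The compounds shown leave open whether the ring or the oxygen of benzyloxy matters, which a plain benzyl or phenyl group would test. Going by these compounds, how an amine or a carboxylic acid at this nitrogen would behave also remains unknown.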